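Aryl piperazine sulfonamide series, arylpiperazine head variation

A few compounds are considered here, and "the series" means these few. Any claim that something is new, unique, unknown or untested is made for them only; others in the source may bear on it.

Measured compounds:
compound 1 `O=C1c2ccccc2S(=O)(=O)N1CCCCN1CCN(c2cccc(Cl)c2Cl)CC1` 2660 nM
compound 2 `COc1ccccc1N1CCN(CCCCCCN2C(=O)c3ccccc3S2(=O)=O)CC1` 779 nM
compound 3 `O=C1c2ccccc2S(=O)(=O)N1CCCCCN1CCN(c2ncccn2)CC1` 7100 nM

In an assay on HEK293 cells for displacement of a labelled ligand from 5-hydroxytryptamine receptor 6 (Homo sapiens) (on this read-out lower numbers stand for stronger inhibition and higher numbers for weaker inhibition), compound 3 gives the highest of the three numbers; compound 1 sits nearest, compound 2 furthest from it, both gaps beyond the scatter. For the measured compounds named here, no pair of these three differs in one place only, so each gap is read as a whole.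

Compound 4 `O=C1c2ccccc2S(=O)(=O)N1CCCCCN1CCN(c2cccc3ccccc23)CC1` is not yet measured. It differs from compound 3 in one place: naphthalen-1-yl in place of pyrimidin-2-yl on an amine nitrogen in a ring.

The step from compound 3 to compound 4 is expected to lower the number, beyond the scatter, an 8.9-fold lower number from compound 3 to compound 4 (0.95 log units; beyond the scatter). Compound 4 is expected to give 800 nM with a range of 150 nM to 4000 nM.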

Compound 4, inhibition constant: 101 nM
For compound 4 the middle estimate is 7.9-fold (0.90 log units) above the measured one; measured number below the stated range.
By their numbers in this assay, from the lowest: compound 4; then compound 2; then compound 1; then compound 3.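

In this assay, naphthalen-1-yl in place of pyrimidin-2-yl on an amine nitrogen in a ring gives a 70-fold lower number from compound 3 to compound 4 (1.85 log units; beyond the scatter), a large step beyond the scatter. For the compounds shown here, this is the first change read at one place with the rest of the structure held constant, and it shows that the number depends strongly on the group at this position. The step replaces one six-membered aromatic ring bearing nitrogen with two carbon-only rings, so ring count and ring nitrogens change together.

Open, on these data alone, is whether a plain phenyl or a quinolin-8-yl group here, or a butyl chain alongside naphthalen-1-yl, would hold the lower number. Nothing measured here bears on the cause of the step.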